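A few compounds are considered here, and "the series" means these few. Any claim that something is new, unique, unknown or untested is made for them only; others in the source may bear on it.

Measured compounds:
- compound 1 `O=C(CCC1=CCN(Cc2ccc(F)cc2)C1=O)NO`: 1940 nM
- compound 2 `Cc1ccc(CCCCN2CC=C(CCC(=O)NO)C2=O)cc1`: 4150 nM
- compound 3 `O=C(CCC1=CCN(Cc2cccc(Br)c2)C1=O)NO`: 1990 nM

All three numbers come from a functional assay on MDA-MB-231 cells (Homo sapiens) for inhibition, read by sulforhodamine B assay; a lower number here means a stronger inhibitor of growth, a higher number a weaker inhibitor of growth. Compound 1 has the lowest number of the three. Compound 3 sits within the usual scatter of compound 1, so no order can be read between the two. Compound 2 has a number beyond the scatter above compound 1; compound 2 differs from compound 1 in more than one place, so this gap is not attributed to a single change.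

Compound 4 `CC(C)(C)c1ccc(CN2CC=C(CCC(=O)NO)C2=O)cc1` has not yet been measured. It differs from compound 1 in one place: tert-butyl in place of fluoro on an aromatic carbon. Among the compounds with values here, no pair among the measured compounds shows this change, so no measured step is on hand for it. The three measured compounds only show that a fluoro, a bromo or a longer chain at the ring-bearing end keep the number within a narrow band in this assay.

Within the data shown here, with no measured step to lean on, a step within the scatter and no clear direction is expected; the expected step from compound 1 is a 1.3-fold higher number from compound 1 to compound 4 (0.11 log units; within the scatter). Compound 4 is estimated at 2500 nM in this assay, with a range from 900 nM to 7000 nM.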

Compound 4, concentration for 50% growth inhibition: 690 nM
For compound 4 the middle estimate is 3.6-fold (0.56 log units) above the measured one; the whole stated range lies above it.
By their numbers in this assay, from the lowest: compound 4; then compounds 1 and 3 (each within the scatter of the next); then compound 2.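

In this assay, within the data shown here, the change from fluoro to tert-butyl on the aromatic carbon para to a large group gives a 2.8-fold lower number from compound 1 to compound 4 (0.45 log units; beyond the scatter), the first step that can be read at a single place. This position therefore responds to the group it carries, and a tert-butyl of 4 heavy atoms is tolerated there in place of a fluoro of 1 heavy atom, with the number falling rather than rising. No measured property on hand accounts for this step.

Among these compounds, with only one step at this carbon, it remains open whether the number follows the size of the group or some other feature of tert-butyl. A trifluoromethyl group, an amine or a carboxylic acid at the same carbon would show how far the trend extends.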